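A few compounds are considered here, and "the series" means these few. Any claim that something is new, unique, unknown or untested is made for them only; others in the source may bear on it.

Working notes on the series. Compound 1 `COCC(C)Nc1n[n+]([O-])c2cc(F)ccc2[n+]1[O-]` in an ADME assay on Vero cells (Chlorocebus sabaeus) for cytotoxicity, read by CellTiter-Glo, with a stated time of 72 h (a higher number here means that more compound is tolerated, a lower number that less compound is tolerated), gives 6.3 ug/mL. Compound 3 `COCC(C)Nc1n[n+]([O-])c2cc(Cl)ccc2[n+]1[O-]` differs from it by chloro in place of fluoro on an aromatic carbon and gives 2.6 ug/mL, the step being a 2.4-fold lower number from compound 1 to compound 3 (0.38 log units; beyond the scatter). Compound 2 `[O-][n+]1nc(N[C@@H]2C[C@H]3CC[C@@H]2C3)[n+]([O-])c2ccc(F)cc21` sits at a limit of this assay, < 2.5 ug/mL. The change from compound 1 to compound 2 is a group of 7 heavy atoms (7 carbon; 2 five-membered non-aromatic rings of carbon only) in place of a group of 5 heavy atoms (4 carbon, 1 oxygen; no ring), on a nitrogen on an aromatic ring, and the step is an at least 2.5-fold lower number from compound 1 to compound 2 (0.40 log units; beyond the scatter); that this value is a limit is recorded in the limit of < 2.5 ug/mL in this assay, at which 1 of the 3 values shown sits. Compound 4 `[O-][n+]1nc(N[C@@H]2C[C@H]3CC[C@@H]2C3)[n+]([O-])c2ccc(Cl)cc21` carries the same change on the core of compound 3, (a group of 7 heavy atoms (7 carbon; 2 five-membered non-aromatic rings of carbon only) in place of a group of 5 heavy atoms (4 carbon, 1 oxygen; no ring), on a nitrogen on an aromatic ring), at the same place. The earlier step of an at least 2.5-fold lower number from compound 1 to compound 2 (0.40 log units; beyond the scatter) was at least modest. Starting from compound 3, the step of a 2.6-fold lower number from compound 3 to compound 4 (0.41 log units; beyond the scatter) is expected to be of like size, probably ending at a limit rather than a number. Compound 4 is estimated at 1 ug/mL in this assay.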

Compound 4, half-maximal cytotoxic concentration: 1.1 ug/mL
Compound 4: the middle estimate sits 1.1-fold (0.04 log units) below what was measured; low and high end bracket the measured number.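

On the chloro-bearing core, the group with 2 five-membered non-aromatic rings of carbon only in place of 1-(methoxymethyl)ethyl gives a 2.4-fold lower number from compound 3 to compound 4 (0.37 log units; beyond the scatter) in this assay, so the change lowers the number on this core as well. Across the two cores the steps run the same way, which is as far as the comparison goes: the same change on two cores in this assay, an at least 2.5-fold lower number (0.40 log units; beyond the scatter) from compound 1 to compound 2 and a 2.4-fold lower number (0.37 log units; beyond the scatter) from compound 3 to compound 4; the limit leaves it open whether they differ

Compound 2, at < 2.5 ug/mL, stands at a limit of the assay, and the step from compound 2 to compound 4 cannot be read.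

Left open is whether the step holds on a core carrying bromo or methoxy in place of chloro or fluoro. Also open, on these data alone, is what a cyclohexyl group or a longer chain on the nitrogen would give.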